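The compounds below may be only part of what the source reports. "The series", "measured", "known", "first", "only" and "open" are said of these compounds alone.

Measured so far in an assay on cells for inhibition of Palmitoleoyl-protein carboxylesterase NOTUM variant C330S (Homo sapiens), read by fluorescence, with a stated time of 40 min; on this read-out lower numbers stand for stronger inhibition and higher numbers for weaker inhibition:
- compound 1 `Cc1cc(C(=O)O)c(C)n1-c1ccc(Cl)c(C(F)(F)F)c1` gives 2100 nM
- compound 2 `Cc1cc(C(=O)O)c(C)n1-c1ccccc1Cl` gives 2300 nM
- compound 3 `Cc1cc(C(=O)O)c(C)n1-c1ccc(Cl)cc1` gives 860 nM

Of these three, compound 3 stands lowest, and its gaps to both other compounds are beyond the usual scatter; compound 1 is the nearer of the two, compound 2 the further. Going by the values given here, the only single-place step among the measured compounds is a 2.4-fold lower number from compound 1 to compound 3 (0.39 log units; beyond the scatter), which shows that taking a trifluoromethyl group off the ring attached to the shared core moved the number down by a modest amount.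

Compound 4 `Cc1cc(C(=O)O)c(C)n1-c1ccc(Cl)cc1Cl` is the next compound. It differs from compound 3 by chloro in place of hydrogen on an aromatic carbon: the chloro enters on an aromatic carbon of a six-membered aromatic ring of carbon only, ortho to a large group and meta to a chloro group. Among the compounds with values here, no measured step adds a chloro at such a place, so the direct evidence is thin. The nearest guide is the step from compound 1 to compound 3, where the compound carrying an extra group on that ring gave the higher number; compound 2, which carries a single chloro group, gives a number well above compound 3. On that basis the step from compound 3 to compound 4 is expected to be small and, if anything, upward, a 1.7-fold higher number from compound 3 to compound 4 (0.24 log units; within the scatter). Compound 4 is therefore estimated at 1500 nM, within a range from 600 nM to 4000 nM.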

Compound 4, half-maximal inhibitory concentration: 430 nM
The estimate for compound 4 lay 3.5-fold (0.54 log units) above the measured number; the measured number lies below the stated range.
By their numbers in this assay, from the lowest: compounds 4 and 3 (each within the scatter of the next); then compounds 1 and 2 (each within the scatter of the next).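

In this assay, the step to the dichloro compound, a 2.0-fold lower number from compound 3 to compound 4 (0.30 log units; within the scatter), shows that a chloro ortho to a large group and meta to a chloro group can be added without a change that stands clear of the scatter, whereas removing trifluoromethyl in the earlier step gave a difference beyond it. Reaching the same compound from the other side gives a 5.3-fold lower number from compound 2 to compound 4 (0.73 log units; beyond the scatter), so the high number of compound 2 does not mean that a chloro at this place rules out a low number: with the second chloro present, compound 4 stands well below compound 2. No measurement here offers an explanation for these differences.

From the compounds shown here alone, it remains open whether this place would accept something other than chloro, such as a methoxy group, a nitrile or an amine, in the same way. The compounds shown also leave open whether the result would hold with an amide in place of the carboxylic acid on the shared core.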